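The compounds below may be only part of what the source reports. "The series", "measured", "known", "first", "only" and "open" are said of these compounds alone.

Measured so far:
compound 1 `COC(=O)C1C(=O)C(C(=O)OC)[C@H](c2cccc([N+](=O)[O-])c2)N(Cc2ccc(OC)cc2)[C@@H]1c1cccc([N+](=O)[O-])c1` — > 100 uM
compound 2 `COC(=O)C1C(=O)C(C(=O)OC)[C@H](c2cccc([N+](=O)[O-])c2)N(Cc2ccc(C)cc2)[C@@H]1c1cccc([N+](=O)[O-])c1` — 49.8 uM
compound 3 `COC(=O)C1=C(O)C[C@H](c2ccccn2)N(Cc2ccc(OC)cc2)[C@@H]1c1ccccn1` — 29.9 uM

In an ADME assay on J774.1 cells (Mus musculus) for cytotoxicity, with a stated time of 48 h (a lower number here means that less compound is needed, a higher number that more compound is needed for the effect), compound 1 reaches only a limit of the assay, > 100 uM; this is the limit of > 100 uM in this assay, at which 1 of the 3 values shown sits. In this assay compound 2 gives 49.8 uM, and compound 3 gives 29.9 uM, two numbers within the scatter of each other. Compound 2 differs from compound 1 by methyl in place of methoxy on an aromatic carbon, and that change made an at least 2.0-fold lower number from compound 1 to compound 2 (0.30 log units; that floor lies within the scatter).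

Compound 4 `COC(=O)C1=C(O)C[C@H](c2ccccn2)N(Cc2ccc(C)cc2)[C@@H]1c1ccccn1` is not yet measured. It differs from compound 3 by methyl in place of methoxy on an aromatic carbon, the same change at the same place as before. How the core of compound 3 differs from the core of compound 1 is not broken down here.

For the measured compounds named here, the one earlier step has a floor that sits within the scatter, so the direction is weakly supported. For compound 4 the expected step is a 1.5-fold lower number from compound 3 to compound 4 (0.17 log units; within the scatter). Compound 4 is estimated at 20 uM in this assay, with a range from 8 uM to 50 uM.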

Compound 4, concentration for half-maximal effect: 34.9 uM
Beside the measured number, compound 4's estimate is 1.7-fold (0.24 log units) below it; low and high end bracket the measured number.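

On the core of compound 3, methyl in place of methoxy gives a 1.2-fold higher number from compound 3 to compound 4 (0.07 log units; within the scatter) in this assay, so this change shows no clear effect on that core. Set beside the earlier step, the comparison reads: the same change on two cores in this assay, an at least 2.0-fold lower number (0.30 log units; that floor lies within the scatter) from compound 1 to compound 2 and a 1.2-fold higher number (0.07 log units; within the scatter) from compound 3 to compound 4; the limit leaves it open whether they differ. The pair of steps shows no reliable direction that carries from one core to the other, and it does not show that the two cores respond differently.

As far as these compounds go, only 4-methoxybenzyl and 4-methylbenzyl are compared on these cores, so it remains open whether an amine or a carboxylic acid at the same place would move the number in this assay beyond the scatter. From the compounds shown here alone, a longer chain at that place is equally open, as is whether any such step would carry across both cores.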